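The source may report more compounds than this note shows. Statements on the series, on what has been measured and on what is new or still open speak of the compounds shown alone.

Measured compounds:
compound 1, `CC/C=C\C[C@H]1C(=O)C=C[C@H]1CC(=O)OCCCC`, in an ADME assay on RAW264.7 cells (Mus musculus) for cytotoxicity, read by MTT assay, with a stated time of 24 h; a higher number here means that more compound is tolerated, a lower number that less compound is tolerated: 31 uM
compound 2, `CC/C=C\C[C@H]1C(=O)C=C[C@H]1CC(=O)Oc1ccccc1OC`, in this assay: 161 uM

Of the two numbers shown, compound 1 stands lowest; compound 2 gives the higher number, and the gap between compound 1 and compound 2 lies beyond the usual scatter. Among the compounds with values here, these two compounds differ in more than one place, so no single step between measured compounds is available here.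

Compound 3, `CC/C=C\C[C@H]1C(=O)C=C[C@H]1CC(=O)OCCO`, has not yet been measured. Relative to compound 1 the change is hydroxy in place of ethyl on a saturated chain carbon, two bonds along the chain from an oxygen next to a carbonyl group. Within the data shown here, no measured pair in this set shares that change, so there is nothing in the numbers to anchor its size. A change of this kind on a chain of this length is expected to move the number only modestly, in the direction of more compound tolerated, and the expected step of a 1.5-fold higher number from compound 1 to compound 3 (0.16 log units; within the scatter) is estimated to sit near the edge of the scatter. Compound 3 is therefore expected to give about 45 uM in this assay, within a range from 15 uM to 130 uM.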

Compound 3, half-maximal toxic concentration: 161 uM
The estimate for compound 3 lay 3.6-fold (0.55 log units) below the measured number, outside the stated range (above it).
By their numbers in this assay, from the lowest: compound 1; then compounds 2 and 3 (each within the scatter of the next).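

In this assay hydroxy in place of ethyl, on a saturated chain carbon two bonds along the chain from an oxygen next to a carbonyl group, gives a 5.2-fold higher number from compound 1 to compound 3 (0.72 log units; beyond the scatter) as a single change, which compounds 1 and 2 could not show. The end of this chain alone, with the core of compound 1 left as it is, can therefore move the tolerated concentration beyond the scatter. Nothing available here accounts for the size of this step.

Read as butyl to 2-hydroxyethyl, the change both shortens the chain and adds hydroxy, and these two parts cannot be told apart from this pair. On these data alone, it remains open whether a longer chain ending in hydroxy, or an amine or a carboxylic acid at the same place, would give a step of similar size.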